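The source may hold more compounds than are shown below. What is called first, only, known or untested is meant among the compounds shown, and "the series" means these compounds.

Measured compounds in an assay on CHO cells, read by calcium flux; on this read-out lower numbers stand for stronger inhibition and higher numbers for weaker inhibition:
- compound 1, `CCc1ccc(NC(=O)c2csc(Cc3c(Cl)cccc3Cl)n2)cc1`: 810 nM
- compound 2, `CN(C)c1ccc(NC(=O)c2csc(Cc3c(Cl)cccc3Cl)n2)cc1`: > 4000 nM, a limit of the assay, not a number
- compound 3, `N#Cc1ccc(NC(=O)c2csc(Cc3c(Cl)cccc3Cl)n2)cc1`: 450 nM

Compound 3 and compound 1 are not separated in this assay, the step being a 1.8-fold lower number from compound 1 to compound 3 (0.26 log units; within the scatter). For compound 2 only a limit is known, (the limit of > 4000 nM in this assay, at which 1 of the 3 values shown sits). Against that limit compound 3 shows an at least 8.8-fold lower number from compound 2 to compound 3 (0.94 log units; beyond the scatter), and compound 1 shows an at least 4.9-fold higher number from compound 1 to compound 2 (0.69 log units; beyond the scatter).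

Compound 4, `O=C(Nc1cccc(Br)c1)c1csc(Cc2c(Cl)cccc2Cl)n1`, is not yet measured. It differs from compound 3 by 3-bromophenyl in place of 4-cyanophenyl on an amide-type nitrogen. The measured steps all exchange the group on the aromatic ring of the amide-bearing part: ethyl, dimethylamino and cyano. Of these, the ethyl-to-cyano step stayed within the scatter, while the dimethylamino step went beyond it. For the measured compounds named here, a bromine, and a 3-position on that ring, appear in none of the measured compounds, so no step speaks directly to compound 4. The expected step is a 1.6-fold higher number from compound 3 to compound 4 (0.19 log units; within the scatter), small and likely within the scatter. Compound 4 is therefore estimated at 700 nM, between 250 nM and 2500 nM.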

Compound 4, half-maximal inhibitory concentration: > 4000 nM
Compound 4 ended at the assay's limit; the forecaster's own chance of this, stated with the estimate: 10%; middle value at least 5.7-fold (0.75 log units) away from the limit.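

In this assay compound 4 gives > 4000 nM, which is a limit of the assay and not a number. Placing 3-bromophenyl on the amide-type nitrogen in place of 4-cyanophenyl gives an at least 8.8-fold higher number from compound 3 to compound 4 (0.94 log units; beyond the scatter), and placing it there in place of 4-ethylphenyl gives an at least 4.9-fold higher number from compound 1 to compound 4 (0.69 log units; beyond the scatter), so this position can lose inhibition with a group other than the dimethylamino-bearing ring of compound 2, the only earlier compound to do so. Compound 2 and compound 4 now share one limit of the assay, so the two cannot be ordered: the limit of > 4000 nM in this assay, at which 2 of the 4 values shown sit.

Bromine and its place on the ring change together in this step, so the compounds shown do not tell which of the two goes with the weaker inhibition. As far as these compounds go, how an aromatic ring bearing a carboxylic acid or a primary amine would read at this position also remains open.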